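Inserting a Carbonyl: Expected Microsomal Stability of Compound 3

A few compounds are considered here, and "the series" means these few. Any claim that something is new, unique, unknown or untested is made for them only; others in the source may bear on it.

Compound 1, `CCCCCOC(=O)N1CCN(C(=O)[C@H](CCC(=O)O)NC(=O)c2cc(N3CCC(C(=O)NCC)CC3)nc(-c3ccccc3)n2)CC1`: in an ADME assay on microsomes from liver (Homo sapiens) for metabolic stability (a higher number here means that more of the compound is left, a lower number that less of the compound is left), compound 1 gives > 80%, a limit of the assay.
Compound 2, `CCCCCOC(=O)N1CCN(C(=O)[C@H](CCC(=O)O)NC(=O)c2cc(N3CCC(N4CCCC4)CC3)nc(-c3ccccc3)n2)CC1`: in this assay compound 2 gives > 80%, also a limit of the assay.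

Compound 2 therefore stands only at a limit, namely (the limit of > 80% in this assay, at which 2 of the 2 values shown sit). The change from compound 2 to compound 3, `CCCCCOC(=O)N1CCN(C(=O)[C@H](CCC(=O)O)NC(=O)c2cc(N3CCC(C(=O)N4CCCC4)CC3)nc(-c3ccccc3)n2)CC1`, is (pyrrolidin-1-yl)carbonyl in place of pyrrolidin-1-yl on a saturated ring carbon. Among the compounds with values here, the one measured step, a step that the two limits leave unreadable from compound 1 to compound 2, bears on this change, yet its size is not readable because both compounds sit at a limit. No step beyond the scatter is expected, estimated as a step that the limit leaves unreadable from compound 2 to compound 3. Compound 3 is expected to give 85%, with a range from 70% to 95%.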

Compound 3, percent of the compound remaining: > 80%
Compound 3: only a limit was reported; the forecaster's own chance of this, stated with the estimate: 70%; the middle value lies beyond the limit too.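

No step can be read among compound 1, compound 2 and compound 3, since each result in this assay is only a limit of the assay: the limit of > 80% in this assay, at which 3 of the 3 values shown sit.

The compounds shown leave open whether these three differ at all in this assay, and by how much.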